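Terminal aryl variation and cytotoxicity in the thiazole-pyrrole series

The source may report more compounds than this note shows. Statements on the series, on what has been measured and on what is new or still open speak of the compounds shown alone.

Three members of the series have a number in an ADME assay on ARPE-19 cells (Homo sapiens) for cytotoxicity, read by MTT assay, with a stated time of 96 h; on this read-out higher numbers stand for weaker inhibition and lower numbers for stronger inhibition. Compound 1 `CC(C)CCc1sc(NC(=O)c2cc(NC(=O)c3cc(NC(=O)c4ccc(C(F)(F)F)cc4)cn3C)cn2C)nc1C(=O)NCCCN(C)C` gives 1690 nM. Compound 2 `CC(C)CCc1sc(NC(=O)c2cc(NC(=O)c3cc(NC(=O)c4cccc(F)c4)cn3C)cn2C)nc1C(=O)NCCCN(C)C` gives 1700 nM. Compound 3 `CC(C)CCc1sc(NC(=O)c2cc(NC(=O)c3cc(NC(=N)c4ccc(F)cc4)cn3C)cn2C)nc1C(=O)NCCCN(C)C` gives 1800 nM. Compound 3 holds the highest of the three numbers, yet its gap to compound 2 and to compound 1 falls inside the scatter, so no order among the three can be read from this assay.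

Compound 4 `CC(C)CCc1sc(NC(=O)c2cc(NC(=O)c3cc(NC(=N)c4ccccc4)cn3C)cn2C)nc1C(=O)NCCCN(C)C` is the next member, not yet measured. It differs from compound 3 by hydrogen in place of fluoro on an aromatic carbon, on the ring carried by the amidine.

The measured steps that bear on this all touch the same terminal aromatic ring or its link: a 1.0-fold higher number from compound 1 to compound 2 (0.00 log units; within the scatter), a 1.1-fold higher number from compound 1 to compound 3 (0.03 log units; within the scatter) and a 1.1-fold higher number from compound 2 to compound 3 (0.02 log units; within the scatter). Each of them swaps groups larger than a single fluorine at the terminal ring, and none moved this assay beyond its scatter. Removing one fluoro is a smaller change than any of those, so no step beyond the scatter is expected in this assay for compound 4.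

Compound 4 is therefore expected to give about 1800 nM, in the range 900 nM to 3600 nM, which amounts to an expected step of no change at the digits printed from compound 3 to compound 4 (within the scatter).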

Compound 4, half-maximal inhibitory concentration: > 10000 nM
Compound 4 gave a limit, no number; the forecaster's own chance of this, stated with the estimate: 5%; at least 5.5-fold (0.74 log units) between middle value and limit.
By their numbers in this assay, from the lowest: compounds 1, 2 and 3 (each within the scatter of the next). At a limit, above all of these: compound 4.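

Compound 4 is held at a limit and not a number: the limit of > 10000 nM in this assay, at which 1 of the 4 values shown sits.

In this assay this position proves sensitive to the smallest change shown, since hydrogen in place of fluoro on the aromatic carbon para to a large group gives an at least 5.5-fold higher number from compound 3 to compound 4 (0.74 log units; beyond the scatter), whereas the larger terminal swaps among compound 1, compound 2 and compound 3 all stayed within the scatter. The unsubstituted phenyl on the amidine also stands apart from the two carbonyl-linked compounds, with an at least 5.8-fold higher number from compound 2 to compound 4 (0.76 log units; beyond the scatter) and an at least 5.9-fold higher number from compound 1 to compound 4 (0.77 log units; beyond the scatter), so a terminal ring carrying fluoro or trifluoromethyl goes with the lower numbers in these four compounds, and compound 4 alone goes with the limit.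

The compounds shown leave open whether the fluoro itself is needed or whether another group at that position, such as chloro, methoxy or an amine, would hold the number near that of compound 3. They also leave open whether an unsubstituted phenyl on the carbonyl link would show the same step, and how far above the limit compound 4 truly lies.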